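This account rests on a few compounds, and the source may have more. Where it says the series, first, only, none or still open, it means among the compounds named here.

Compound 1 is `Cc1nc2c(c(-c3cc(F)c4c(c3C)CCCO4)c1[C@H](OC(C)(C)C)C(=O)O)CN(CCCc1cccc(F)c1)CC2`. In an ADME assay on MT2 cells (Homo sapiens) for cytotoxicity, read by XTT assay, with a stated time of 4 days (on this read-out lower numbers stand for higher toxicity in this test and higher numbers for lower toxicity in this test), compound 1 gives only a limit, > 40000 nM, and no number. Compound 2, `Cc1ccc(-c2c3c(nc(C)c2C(OC(C)(C)C)C(=O)O)CCN(C)C3)cc1`, shares the core. In this assay compound 2 likewise returns only a limit, > 40000 nM. Where compound 1 stands is thus fixed solely by the limit of > 40000 nM in this assay, at which 2 of the 2 values shown sit; neither of the two values is a number, so no order between compound 1 and compound 2 can be drawn from them. The next member is compound 3, `Cc1cccc(CCCN2CCc3nc(C)c([C@H](OC(C)(C)C)C(=O)O)c(-c4cc(F)c5c(c4C)CCCO5)c3C2)c1`. Relative to compound 1 the change is methyl in place of fluoro on an aromatic carbon. Within the data shown here, no measured pair in the set differs in one place, so the size of such a change on this read-out is not known from these data. Because compound 1 sits at > 40000 nM, nothing in the set points to a step beyond the usual scatter. The step that the limit leaves unreadable from compound 1 to compound 3 is therefore expected to be none beyond the scatter. Compound 3 is estimated at 60000 nM, between 30000 nM and 150000 nM, and is expected most likely to be reported again only as a limit in this assay.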

Compound 3, half-maximal cytotoxic concentration: > 40000 nM
Compound 3 gave a limit, no number; the forecaster's own chance of this, stated with the estimate: 85%; the middle value is on the limit's open side.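

Compound 1 and compound 3 both return only limits in this assay, so no step can be read for methyl in place of fluoro on an aromatic carbon: the limit of > 40000 nM in this assay, at which 3 of the 3 values shown sit.

The compounds shown leave open how large that step is, and whether any member of the series gives a number in this assay rather than a limit.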